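One aryl swap on a shared core, with little to go on

The source may report more compounds than this note shows. Statements on the series, on what has been measured and on what is new or still open speak of the compounds shown alone.

Compound 1, `Cc1ccc(-n2cc(COc3ccc4c(c3)CCC4)nn2)cc1`: in an ADME assay on HEK293 cells (Homo sapiens) for inhibition, read by MTT assay, with a stated time of 48 h, tested at 25 uM (a higher number here means more inhibition at the concentration tested (going by the name of the read-out), a lower number less inhibition), compound 1 is recorded as "not determined" (no result reported).
Compound 2, `COc1ccccc1NC(=O)Cn1cc(COc2ccc3c(c2)CCC3)nn1`: gives 23.4% in this assay.
Compound 3, `O=C(Cn1cc(COc2ccc3c(c2)CCC3)nn1)Nc1cccc(Cl)c1`: in this assay compound 3 is recorded as "not determined" (no result reported).
Compound 4, `Brc1ccccc1-n1cc(COc2ccc3c(c2)CCC3)nn1`: not yet measured.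

Compound 1 stands nowhere on the numbers: in this assay it has no reported value, and compound 3, which shares the same core, also has none. Among the compounds with values here, the only number in the set belongs to compound 2, whose reading of 23.4% sits in a low range, and compound 2 carries a different kind of side arm from compound 1, so it tells little directly about the pair at hand.

The change from compound 1 to compound 4 is a single swap on the core: 2-bromophenyl in place of 4-methylphenyl on an aromatic nitrogen. Within the data shown here, no step between measured compounds is available to say how such a swap moves a reading in this assay, so nothing here points to a shift beyond the usual scatter in either direction.

With compound 2 as the only anchor, compound 4 is estimated to give about 22%, with a range from 0% to 50%, and the width of that range reflects how thin the evidence is.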

Compound 4, a percentage reported as inhibition, at one concentration (the size of the read-out at that concentration, not a potency): 16.5%
The estimate for compound 4 lay 5.5 percentage points above the measured number; measured number inside the range.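

In this assay, within the data shown here, compound 4 gives 16.5% but compound 1 has no single number, so no step between compound 1 and compound 4 can be read. The compounds shown leave open how swapping 4-methylphenyl for 2-bromophenyl on the shared core moves this reading. No further evidence bears on this result.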